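The source may hold more compounds than are shown below. What is called first, only, known or untested is meant among the compounds shown, and "the series" means these compounds.

The series shares a core that carries an aryl group on the aromatic carbon beside the ring nitrogen. Compound 3 `FC(F)(F)Oc1ccc(Nc2cc(-c3cccc4[nH]ccc34)ncn2)cc1`, bearing 1H-indol-4-yl there, gives 3790 nM in an ADME assay on BaF3 cells (Mus musculus) for cytotoxicity; on this read-out lower numbers stand for an effect already at smaller amounts and higher numbers for an effect only at larger amounts of compound. Among the two plain numbers, compound 3 stands highest, and its nearest neighbour is compound 2 `CS(=O)(=O)Nc1ccc(-c2cc(Nc3ccc(OC(F)(F)F)cc3)ncn2)cc1`, which gives 2210 nM; the two lie within the usual scatter of each other. Compound 1 `FC(F)(F)Oc1ccc(Nc2cc(-c3ccc4[nH]ccc4c3)ncn2)cc1` reports only a limit, > 10000 nM. Among the compounds with values here, that limit, (the limit of > 10000 nM in this assay, at which 1 of the 3 values shown sits), sets the one measured step, an at least 2.6-fold lower number from compound 1 to compound 3 (0.42 log units; beyond the scatter).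

Compound 4 `NC(=O)c1ccc(-c2cc(Nc3ccc(OC(F)(F)F)cc3)ncn2)cc1` is not yet measured. It differs from compound 3 by 4-carbamoylphenyl in place of 1H-indol-4-yl on an aromatic carbon. Within the data shown here, the only step in hand, from compound 1 to compound 3, moves between two indolyl groups and is at least modest; it does not directly concern a carbamoylphenyl group. Compound 2, whose aryl group is likewise a phenyl ring carrying a single polar substituent, shows a number within the scatter of compound 3, so no step beyond the scatter is expected here.

Compound 4 is therefore estimated at 3000 nM, with a range from 1000 nM to 10000 nM, which means an expected step of a 1.3-fold lower number from compound 3 to compound 4 (0.10 log units; within the scatter).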

Compound 4, half-maximal effective concentration: > 10000 nM
Compound 4: no number, only a limit; the forecaster's own chance of this, stated with the estimate: 25%; middle value at least 3.3-fold (0.52 log units) from the limit.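

Compound 4, with 4-carbamoylphenyl on the aromatic carbon next to the ring nitrogen, gives only a limit in this assay and no number, as compound 1 does: the limit of > 10000 nM in this assay, at which 2 of the 4 values shown sit. Set against the plain numbers, 4-carbamoylphenyl in place of 1H-indol-4-yl gives an at least 2.6-fold higher number from compound 3 to compound 4 (0.42 log units; beyond the scatter), and carbamoyl in place of methanesulfonamido on the same phenyl ring gives an at least 4.5-fold higher number from compound 2 to compound 4 (0.65 log units; beyond the scatter). Within the data shown here, compound 2 had been the only example with a singly substituted phenyl ring at this position, so compound 4 adds two things: the read-out here changes with the substituent on that ring, and the limit is reached not only with an indolyl group, as in compound 1, but also with a phenyl ring.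

From the compounds shown here alone, compound 1 and compound 4 both stand at a limit, so the step between them cannot be read, and how far either lies past that limit stays open. The compounds shown also leave open where an amine or a carboxylic acid in place of carbamoyl on the phenyl ring would fall in this assay.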